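Carboxy to carbamoyl on the shared core

The source may hold more compounds than are shown below. What is called first, only, known or untested is meant among the compounds shown, and "the series" means these compounds.

Values in a functional assay on HeLa cells (Homo sapiens) for cytotoxicity; on this read-out lower numbers stand for stronger inhibition and higher numbers for weaker inhibition:
compound 1 (`COC(=O)C1CCC2(CC1)OOC1(CCCCC1)OO2`) 75900 nM
compound 2 (`O=C(O)C1CCC2(CC1)OOC1(CCCCC1)OO2`) 120000 nM
compound 3 (`NC(=O)C1CCC2(CC1)OOC1(CCCCC1)OO2`) not yet measured

Compound 2 gives 120000 nM in this assay and stands level with compound 1 within the scatter. The change to compound 3 is amino in place of hydroxy on a carbonyl carbon. Among the measured compounds shown here, the one measured step bearing on it is a 1.6-fold higher number from compound 1 to compound 2 (0.20 log units; within the scatter) and it stays within the scatter. For the measured compounds named here, no measured compound carries the amino group, so this expectation rests on that single step. The estimated step is a 1.2-fold lower number from compound 2 to compound 3 (0.08 log units; within the scatter) and none beyond the scatter is expected. Compound 3 is expected at 100000 nM (estimated range 45000 nM to 220000 nM).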

Compound 3, half-maximal inhibitory concentration: 115000 nM
The estimate for compound 3 lay 1.2-fold (0.06 log units) below the measured number; the range from low to high includes it.
By their numbers in this assay, from the lowest: compounds 1, 3 and 2 (each within the scatter of the next).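

In this assay amino in place of hydroxy on a carbonyl carbon gives a 1.0-fold lower number from compound 2 to compound 3 (0.02 log units; within the scatter) and amino in place of methoxy gives a 1.5-fold higher number from compound 1 to compound 3 (0.18 log units; within the scatter) on the same carbon. Methoxy, hydroxy and amino at this place therefore all stand level within the scatter, so the flat result now holds across three groups rather than two. No supporting data bear on why these groups stand level.

As far as these compounds go, whether an amine, a longer chain or a nitrile at this place would move the number beyond the scatter stays open. Changes elsewhere on the shared core also stay open.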